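The source may report more compounds than this note shows. Statements on the series, on what has been measured and on what is new or still open speak of the compounds shown alone.

Measured so far in an ADME assay on Vero cells (Chlorocebus sabaeus) for cytotoxicity, read by MTT assay, with a stated time of 48 h; on this read-out higher numbers stand for weaker inhibition and lower numbers for stronger inhibition:
compound 1, `CC1COC2(CCN(c3cc(=O)c4cc(C(F)(F)F)cc([N+](=O)[O-])c4o3)CC2)O1`, gives 18.9 ug/mL
compound 2, `O=c1nc(NCC2CCCCC2)oc2c([N+](=O)[O-])cc(C(F)(F)F)cc12`, gives 29.7 ug/mL
compound 3, `CC1CN(c2cc(=O)c3cc(C(F)(F)F)cc([N+](=O)[O-])c3s2)CCN1CC1CCCCC1`, gives > 64 ug/mL

Compound 1 and compound 2 carry numbers in this assay. Compound 3 does not: its result is a limit of the assay, not a number, and the limit of > 64 ug/mL in this assay, at which 1 of the 3 values shown sits, is all that is known of it. For the measured compounds named here, no two of the three measured compounds differ in a single place, so no measured step is available to set a scale for the series; the three values are only recorded as they stand.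

The next compound, compound 4, `O=c1cc(N2CCN(CC3CCCCC3)CC2)sc2c([N+](=O)[O-])cc(C(F)(F)F)cc12`, is to be measured in this assay. It differs from compound 3 in one place: hydrogen in place of methyl on a saturated ring carbon. Since compound 3 sits at the limit, the direction of a step from it can only be read downward or as no change. Going by the values given here, with so small a change on a saturated ring carbon, and no measured step to lean on, no movement beyond the scatter is expected in this assay, but the limit may well not be reached again. Compound 4 is therefore expected to give 50 ug/mL, within 22 ug/mL to 110 ug/mL, which means an estimated step of an at least 1.2-fold lower number from compound 3 to compound 4 (0.10 log units; that floor lies within the scatter).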

Compound 4, half-maximal inhibitory concentration: > 64 ug/mL
Compound 4: only a limit was reported; the forecaster's own chance of this, stated with the estimate: 50%; at least 1.2-fold (0.10 log units) between middle value and limit.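

In this assay, compound 3 and compound 4 both give limits of the assay rather than numbers, so no step can be read between them: the limit of > 64 ug/mL in this assay, at which 2 of the 4 values shown sit.

The compounds shown leave open whether hydrogen in place of methyl on a saturated ring carbon changes the value at all, and what number either compound would carry.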